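This account rests on a few compounds, and the source may have more. Where it says the series, first, only, none or still open, it means among the compounds named here.

Compound 2 `Cc1ccccc1C(=O)Nc1cccc(/C=C/C(=O)c2nc3ccccc3[nH]2)c1` stands lowest of the two numbers in a functional assay on HCT-116 cells (Homo sapiens) for antiproliferative activity, read by MTT assay, with a stated time of 48 h (on this read-out lower numbers stand for stronger inhibition and higher numbers for weaker inhibition), with compound 2 giving 1870 nM; its nearest neighbour is compound 1 `O=C(Nc1cccc(/C=C/C(=O)c2nc3ccccc3[nH]2)c1)c1ccccc1`, which in this assay gives 2440 nM, and the step of a 1.3-fold lower number from compound 1 to compound 2 (0.12 log units; within the scatter) lies within the scatter. Compound 3 `Cc1ccc(S(=O)(=O)Nc2cccc(/C=C/C(=O)c3nc4ccccc4[nH]3)c2)cc1` differs from compound 2 by (4-methylphenyl)sulfonyl in place of (2-methylphenyl)carbonyl on a nitrogen on an aromatic ring. Within the data shown here, the only measured step, from compound 1 to compound 2, concerns a methyl in place of hydrogen on an aromatic carbon and does not touch the group on the nitrogen, so nothing measured bears directly on this change, and the account expects no step beyond the scatter, with wide uncertainty. The number for compound 3 in this assay is therefore estimated at 2500 nM, in a range from 800 nM to 8000 nM, which means an expected step of a 1.3-fold higher number from compound 2 to compound 3 (0.13 log units; within the scatter).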

Compound 3, half-maximal inhibitory concentration: 1990 nM
Estimate against measurement, compound 3: 1.3-fold (0.10 log units) above; the range from low to high includes it.
By their numbers in this assay, from the lowest: compounds 2, 3 and 1 (each within the scatter of the next).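

With (4-methylphenyl)sulfonyl in place of (2-methylphenyl)carbonyl on a nitrogen on an aromatic ring, this assay gives a 1.1-fold higher number from compound 2 to compound 3 (0.03 log units; within the scatter), and with the same group in place of benzoyl it gives a 1.2-fold lower number from compound 1 to compound 3 (0.09 log units; within the scatter). Among these compounds, the group on this nitrogen had been the same kind of carbonyl group in the earlier compounds, and these steps show that a sulfonyl group there gives a number within the scatter of both carbonyl compounds. Nothing available explains this result.

From the compounds shown here alone, each step changes the linking group and the aryl part together, so the contribution of each stays open. Going by these compounds, it also stays open whether this nitrogen would hold its number within the same scatter with a free amine, an acetyl group or a longer alkyl chain, or with a carboxylic acid on the aromatic ring of the group.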